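The compounds below may be only part of what the source reports. "The series", "measured", "known", "first", "only" and "open" are said of these compounds alone.

In a functional assay on CNE-2 cells (Homo sapiens) for antiproliferative activity, read by sulforhodamine B assay, with a stated time of 48 h (on this read-out higher numbers stand for weaker inhibition and lower numbers for stronger inhibition), compound 1 `COc1ccc(OC)c(/C=C/C(=O)/C=C(O)/C=C/c2cc(OC)ccc2OC)c1` gives 14700 nM. Compound 2 `COc1cc(C=C(C(=O)/C=C/c2cccc(OC)c2OC)C(=O)/C=C/c2cccc(OC)c2OC)ccc1O` gives 280 nM, and compound 3 `COc1ccc(C=C(C(=O)/C=C/c2cccc(OC)c2OC)C(=O)/C=C/c2cccc(OC)c2OC)cc1OC` gives 280 nM, level with compound 2, the two together holding the lowest of the three numbers. Compound 4 `COc1cc(OC)c(C=C(C(=O)/C=C/c2cccc(OC)c2OC)C(=O)/C=C/c2cccc(OC)c2OC)c(OC)c1` has not yet been measured. It differs from compound 3 by 2,4,6-trimethoxyphenyl in place of 3,4-dimethoxyphenyl on a double-bonded chain carbon bound to a double-bonded chain carbon. For the measured compounds named here, only one measured step touches this group, and it shows no change at the digits printed from compound 2 to compound 3 (within the scatter). Going by the values given here, that step offers no sign of a large shift, but no measured compound carries the new pattern, so the evidence is thin. A small rise in the number is the cautious expectation, with an expected step of a 1.6-fold higher number from compound 3 to compound 4 (0.21 log units; within the scatter). For compound 4 the estimated value is 450 nM, with an expected range of 130 nM to 2000 nM.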

Compound 4, half-maximal inhibitory concentration: 630 nM
Beside the measured number, compound 4's estimate is 1.4-fold (0.15 log units) below it; low and high end bracket the measured number.
By their numbers in this assay, from the lowest: compounds 2 and 3 (each within the scatter of the next); then compound 4; then compound 1.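

In this assay the step of a 2.3-fold higher number from compound 3 to compound 4 (0.35 log units; beyond the scatter) and the step of a 2.3-fold higher number from compound 2 to compound 4 (0.35 log units; beyond the scatter) both follow the entry of 2,4,6-trimethoxyphenyl on a double-bonded chain carbon bound to a double-bonded chain carbon. For the compounds shown here, the earlier step, no change at the digits printed from compound 2 to compound 3 (within the scatter), left the number flat, so this is the first sign that the substitution of this aromatic ring can move the number here, if only modestly. Nothing shown explains the rise.

Going by these compounds, it remains open whether the rise follows the added methoxy group or the pattern of the methoxy groups. On these data alone, how an amine or a carboxylic acid on this ring would behave also remains open.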